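Shifting the Naphthalene Attachment Point in Compound 1

This account rests on a few compounds, and the source may have more. Where it says the series, first, only, none or still open, it means among the compounds named here.

Compound 1 `COC(C(=O)OC(C)Cn1cnc2c1c(=O)n(C)c(=O)n2C)c1cccc2ccccc12` was tested in a functional assay on MCF7 cells (Homo sapiens) for antiproliferative activity, read by MTT assay, with a stated time of 72 h, tested at 25 uM (on this read-out higher numbers stand for a weaker effect at the one concentration tested and lower numbers for a stronger effect), where compound 1 gives 92.6%. Its companion compound 2 `CC(Cn1cnc2c1c(=O)n(C)c(=O)n2C)OC(=O)CC(=O)c1ccc(F)cc1` gives 88.5% in this assay; the two numbers lie within the usual scatter of each other, so neither stands apart. Compound 3 `COC(C(=O)OC(C)Cn1cnc2c1c(=O)n(C)c(=O)n2C)c1ccc2ccccc2c1` has not yet been measured. It differs from compound 1 in one place: naphthalen-2-yl in place of naphthalen-1-yl on a saturated chain carbon bound to a carbonyl carbon and an oxygen on a saturated carbon. Among the measured compounds shown here, no measured pair shows what such a rearrangement does here. With the same atoms merely joined differently, the expected step is a number 2.6 percentage points lower from compound 1 to compound 3 (within the scatter), small and not beyond the scatter in either direction. For compound 3 the estimated value is 90%, with a range from 76% to 100%.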

Compound 3, a percentage reported as activity, at one concentration (the size of the read-out at that concentration, not a potency): 93.5%
Compound 3: the middle estimate sits 3.5 percentage points below what was measured, within the range that was stated.
By their numbers in this assay, from the lowest: compounds 2, 1 and 3 (each within the scatter of the next).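

Swapping naphthalen-1-yl for naphthalen-2-yl gives a number 0.9 percentage points higher from compound 1 to compound 3 (within the scatter) in this assay, the first step here between compounds that differ in one place. At this position on the saturated chain carbon, changing only the naphthalene attachment point therefore leaves the read-out within the usual scatter. Nothing available explains this result. Still open, as far as these compounds go, is whether replacing the naphthalene at this position with an amine or a carboxylic acid would move the number beyond the scatter. From the compounds shown here alone, the effect of a longer chain there is equally open.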